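A few compounds are considered here, and "the series" means these few. Any claim that something is new, unique, unknown or untested is made for them only; others in the source may bear on it.

Going by the values given here, in a functional assay on MIA PaCa-2 cells (Homo sapiens) for cytotoxicity, read by MTT assay, with a stated time of 4 h (a higher number here means a weaker inhibitor, a lower number a stronger inhibitor), compound 1 (`COC1=CC(=O)c2c(COc3ccc([N+](=O)[O-])cc3)c(C)n(C)c2C1=O`) gives 638 nM and compound 2 (`COC1=CC(=O)c2c(COc3ccc([N+](=O)[O-])cc3F)c(C)n(C)c2C1=O`) gives 529 nM, so compound 1 stands within the scatter of the only other measured compound. Compound 3 (`COC1=CC(=O)c2c(COc3ccc(C(F)(F)F)cc3)c(C)n(C)c2C1=O`) keeps the core of compound 1 but carries trifluoromethyl in place of nitro on an aromatic carbon, para to a large group: trifluoromethyl in place of nitro on an aromatic carbon. Among the compounds with values here, only one measured step bears on this change, the fluoro in place of hydrogen on an aromatic carbon, a 1.2-fold lower number from compound 1 to compound 2 (0.08 log units; within the scatter). Within the data shown here, that step leaves the nitro group untouched, and no measured compound lacks nitro, so the data offer no direct guide to this replacement. On these data alone, no step beyond the scatter is therefore expected in this assay, and the direction remains open. The estimated step is a 1.1-fold higher number from compound 1 to compound 3 (0.04 log units; within the scatter). Compound 3 is estimated at 700 nM, with an expected range from 250 nM to 2000 nM.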

Compound 3, half-maximal inhibitory concentration: 496 nM
Beside the measured number, compound 3's estimate is 1.4-fold (0.15 log units) above it; the measured number falls inside the stated range.
By their numbers in this assay, from the lowest: compounds 3, 2 and 1 (each within the scatter of the next).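

In this assay, trifluoromethyl in place of nitro on an aromatic carbon, para to a large group, gives a 1.3-fold lower number from compound 1 to compound 3 (0.11 log units; within the scatter). Compounds 1 and 2 both carry nitro, so they could not show whether the group can be exchanged; compound 3 shows that, in this assay, nitro can give way to trifluoromethyl with no step beyond the scatter, and its number also lies within the scatter of that of compound 2. No measurement offered here explains this result. The compounds shown leave open whether an amine, a carboxylic acid or a methoxy group at this place would also stay within the scatter. They also leave open whether fluoro in place of hydrogen would give a similar step alongside trifluoromethyl.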